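This account rests on a few compounds, and the source may have more. Where it says the series, first, only, none or still open, it means among the compounds named here.

In an ADME assay on WI-38 cells (Homo sapiens) for cytotoxicity, read by MTT assay, with a stated time of 72 h (a lower number here means a stronger inhibitor, a higher number a weaker inhibitor), compound 1 `O=C(CCc1cccc2c1B(O)OC2)Nc1cccc(Br)c1` gives 20000 nM and compound 2 `CC(C)c1cccc(NC(=O)CCc2cccc3c2B(O)OC3)c1` gives 22000 nM so the two stand level within the scatter. Compound 3 `C#Cc1cccc(NC(=O)CCc2cccc3c2B(O)OC3)c1` carries ethynyl in place of isopropyl on an aromatic carbon on the same ring of the shared core. Among the compounds with values here, one measured step bears on this change: a 1.1-fold higher number from compound 1 to compound 2 (0.04 log units; within the scatter) with isopropyl in place of bromo, and it stays within the scatter. On that single step, no change beyond the scatter is expected in this assay for ethynyl. The estimated step is a 1.1-fold lower number from compound 2 to compound 3 (0.04 log units; within the scatter) and it is expected to stay within the scatter. For compound 3 the estimated value is 20000 nM with an expected range of 8000 nM to 45000 nM in this series.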

Compound 3, half-maximal inhibitory concentration: > 100000 nM
Compound 3 gave a limit, no number (the forecaster's own chance of this, stated with the estimate: 10%); middle value at least 5.0-fold (0.69 log units) from the limit.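

In this assay this position proves sensitive to its substituent, which bromo and isopropyl did not reveal: ethynyl gives an at least 4.5-fold higher number from compound 2 to compound 3 (0.65 log units; beyond the scatter) and an at least 5.0-fold higher number from compound 1 to compound 3 (0.69 log units; beyond the scatter). Compound 3 reads > 100000 nM, which is a limit and not a number. Both steps are thus lower bounds only, and the full size of the change stays unknown: the limit of > 100000 nM in this assay, at which 1 of the 3 values shown sits.

Open, going by these compounds, is whether a nitrile, an amine or a carboxylic acid at this position would stay level with compound 1 and compound 2 or move as ethynyl does.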